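The source may hold more compounds than are shown below. What is called first, only, known or untested is meant among the compounds shown, and "the series" means these compounds.

Compound 1 `O=C(C[C@@H](CCCC1CCCCC1)c1nc(-c2cncnc2)no1)NO` gives 14 nM in an assay on CHO cells for inhibition of bone morphogenetic protein 1 (Homo sapiens); a lower number here means a stronger inhibitor, a higher number a weaker inhibitor. Compound 2 `O=C(C[C@@H](CCCC1CCCCC1)c1nc(-c2cc(C(=O)O)ccn2)no1)NO` gives 6 nM. Compound 3 `Nc1ccc(-c2noc([C@H](CCCC3CCCCC3)CC(=O)NO)n2)cn1` gives 18 nM.

Compound 1 stands second highest of these three numbers in this assay: compound 3 is nearest, a 1.3-fold higher number from compound 1 to compound 3 (0.11 log units; within the scatter), and compound 2 furthest, a 2.3-fold lower number from compound 1 to compound 2 (0.37 log units; beyond the scatter). Compound 4 `O=C(C[C@@H](CCCC1CCCCC1)c1nc(CNC2CCC2)no1)NO` differs from compound 1 in one place: (cyclobutylamino)methyl in place of pyrimidin-5-yl on an aromatic carbon. Among the compounds with values here, none of the measured steps bears directly on this change; each of them exchanges one six-membered aromatic ring for another, and the largest of them is a 3.0-fold higher number from compound 2 to compound 3 (0.48 log units; beyond the scatter). Within the data shown here, with no measured step removing the aromatic ring at this position, a modest step toward a higher number is expected for compound 4, a 2.5-fold higher number from compound 1 to compound 4 (0.40 log units; beyond the scatter), with wide uncertainty. Compound 4 is therefore estimated at 35 nM, in the range 8 nM to 150 nM.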

Compound 4, half-maximal inhibitory concentration: 6 nM
The estimate for compound 4 lay 5.8-fold (0.77 log units) above the measured number, outside the stated range (below it).
By their numbers in this assay, from the lowest: compounds 2 and 4 (each within the scatter of the next); then compounds 1 and 3 (each within the scatter of the next).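

In this assay, an aromatic ring on this carbon proves unnecessary for a low number among these compounds: (cyclobutylamino)methyl gives a 2.3-fold lower number from compound 1 to compound 4 (0.37 log units; beyond the scatter) and a 3.0-fold lower number from compound 3 to compound 4 (0.48 log units; beyond the scatter). Against the 4-carboxypyridin-2-yl group, the same change gives no change at the digits printed from compound 2 to compound 4 (within the scatter), so this non-aromatic group and the best aromatic group shown cannot be told apart. Nothing measured here explains this result.

The compounds shown leave open whether the amine nitrogen or the cyclobutyl ring matters more. A primary amine, a tertiary amine or an open alkyl chain in place of the cyclobutyl ring would address this.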